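The source may report more compounds than this note shows. Statements on the series, on what has been measured and on what is new or still open speak of the compounds shown alone.

In a functional assay on MDA-MB-468 cells (Homo sapiens) for antiproliferative activity, read by CellTiter-Glo, with a stated time of 96 h (on this read-out higher numbers stand for weaker inhibition and lower numbers for stronger inhibition), three compounds sharing one core have been measured. Compound 1 `COc1ccc(-c2nsc3c2NC(=O)CC3c2cccc(OC)c2)cc1` gives 662 nM, compound 2 `COc1ccc(-c2nsc3c2NC(=O)CC3c2ccc3c(c2)OCCO3)cc1` gives 451 nM and compound 3 `COc1ccc(-c2nsc3c2NC(=O)CC3c2cccc(Cl)c2)cc1` gives 752 nM, so compound 3 lies within the usual scatter of both others. Compound 4 `COc1ccc(-c2nsc3c2NC(=O)CC3c2cccc(F)c2)cc1` differs from compound 3 in one place: fluoro in place of chloro on an aromatic carbon. Within the data shown here, no measured step makes this exact swap. The closest measured change is also a single swap at that place, a 1.1-fold higher number from compound 1 to compound 3 (0.06 log units; within the scatter), so no step beyond the scatter is expected in this assay. The expected change is a 1.1-fold lower number from compound 3 to compound 4 (0.03 log units; within the scatter). For compound 4 the estimated value is 700 nM, with an expected range of 330 nM to 1500 nM.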

Compound 4, half-maximal inhibitory concentration: 1410 nM
Beside the measured number, compound 4's estimate is 2.0-fold (0.30 log units) below it; the measured number falls inside the stated range.
By their numbers in this assay, from the lowest: compounds 2, 1, 3 and 4 (each within the scatter of the next, the first and the last beyond it).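

On the aromatic ring, at the carbon meta to a large group, this assay now shows a change beyond the scatter at this place, though a modest one: a 2.1-fold higher number from compound 1 to compound 4 (0.33 log units; beyond the scatter). The swap from chloro to fluoro stays within the scatter (a 1.9-fold higher number from compound 3 to compound 4 (0.27 log units; within the scatter)), so only methoxy and fluoro can be told apart here, and chloro cannot be separated from either. No measurement available here explains this difference. Still open, from the compounds shown here alone, is whether an amine, a carboxylic acid or a longer chain at this place would move the number further.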